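This account rests on a few compounds, and the source may have more. Where it says the series, first, only, none or still open, it means among the compounds named here.

Measured compounds in a functional assay on BXPC-3 cells (Homo sapiens) for antiproliferative activity, read by MTT assay, with a stated time of 24 h; on this read-out higher numbers stand for weaker inhibition and lower numbers for stronger inhibition:
- compound 1 `CCn1c(C(=O)NCCNC(=O)OC(C)(C)C)ccc1C(CC)(CC)c1ccc(OCS(=O)(=O)c2ccccc2)c(C)c1`: > 50000 nM
- compound 2 `CCN(CC)CCNC(=O)c1ccc(C(CC)(CC)c2ccc(OCS(=O)(=O)c3ccccc3)c(C)c2)n1CC`: 6270 nM
- compound 3 `CCn1c(C(=O)NCCO)ccc1C(CC)(CC)c1ccc(OCS(=O)(=O)c2ccccc2)c(C)c1`: 19900 nM

The value of compound 1 is a limit of this assay, not a number. Of the two numbers that were obtained, compound 2 has the lower one, and its nearest neighbour is compound 3, separated by a 3.2-fold higher number from compound 2 to compound 3 (0.50 log units; beyond the scatter). Both measured steps that leave compound 1, an at least 7.9-fold lower number from compound 1 to compound 2 (0.90 log units; beyond the scatter) and an at least 2.5-fold lower number from compound 1 to compound 3 (0.40 log units; beyond the scatter), run past a limit of > 50000 nM in this assay, at which 1 of the 3 values shown sits, and so set only a floor on their size.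

Compound 4 `CCn1c(C(=O)N[C@@H](CO)CCCO)ccc1C(CC)(CC)c1ccc(OCS(=O)(=O)c2ccccc2)c(C)c1` has not been measured in this assay. It differs from compound 2 in one place: a group of 7 heavy atoms (5 carbon, 2 oxygen; no ring) in place of a group of 7 heavy atoms (6 carbon, 1 nitrogen; no ring), on an amide-type nitrogen. The step that bears most directly on this change is a 3.2-fold higher number from compound 2 to compound 3 (0.50 log units; beyond the scatter), where a hydroxy-bearing chain replaced the diethylamino-bearing one and the number rose beyond the scatter. The group entering compound 4 likewise carries hydroxy groups and no diethylamino, so a step of similar size and direction is expected. The expected step is a 3.2-fold higher number from compound 2 to compound 4 (0.50 log units; beyond the scatter). Compound 4 is therefore estimated at 20000 nM, with a range from 8000 nM to 50000 nM.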

Compound 4, half-maximal inhibitory concentration: 16400 nM
Beside the measured number, compound 4's estimate is 1.2-fold (0.09 log units) above it; the measured number falls inside the stated range.
By their numbers in this assay, from the lowest: compound 2; then compounds 4 and 3 (each within the scatter of the next). At a limit, above all of these: compound 1.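

In this assay, a second hydroxy-bearing group on the amide-type nitrogen reads like the first: 3-hydroxypropyl in place of hydrogen on the saturated chain carbon bound to an amide-type nitrogen and a saturated chain carbon gives a 1.2-fold lower number from compound 3 to compound 4 (0.08 log units; within the scatter). Replacing 2-(diethylamino)ethyl at this place thus costs activity with this second hydroxy-bearing group as well, a 2.6-fold higher number from compound 2 to compound 4 (0.42 log units; beyond the scatter), and compound 2 keeps the lowest number of the series. Compound 1 remains at a limit, so an at least 3.0-fold lower number from compound 1 to compound 4 (0.48 log units; beyond the scatter) gives only a floor: the limit of > 50000 nM in this assay, at which 1 of the 4 values shown sits.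

The compounds shown leave open whether a dimethylamino or morpholino group on the same chain, or a carboxylic acid, would give a number like that of compound 2. Going by these compounds, how a longer chain carrying the diethylamino group would read also stays open.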